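The source may hold more compounds than are shown below. What is called first, only, known or untested is meant among the compounds shown, and "the series" means these compounds.

Working notes on the series, read in a functional assay on A549 cells (Homo sapiens) for antiproliferative activity, read by MTT assay, with a stated time of 48 h; on this read-out higher numbers stand for weaker inhibition and lower numbers for stronger inhibition. Compound 1 (`COc1cccc(C(=O)Nc2nnc(/C=C/c3cc(OC)c(OC)c(OC)c3Br)s2)c1`) gives 60 nM, compound 2 (`COc1cc(/C=C/c2nnc(NC(=O)c3ccc(Br)cc3)s2)c(Br)c(OC)c1OC`) gives 160 nM and compound 3 (`COc1cc(/C=C/c2nnc(NC(=O)c3cccc(Cl)c3)s2)c(Br)c(OC)c1OC`) gives 70 nM. Compound 3 stands close to compound 1, with a 1.2-fold higher number from compound 1 to compound 3 (0.07 log units; within the scatter), and apart from compound 2, with a 2.3-fold lower number from compound 2 to compound 3 (0.36 log units; beyond the scatter). Compound 4 (`COc1cc(/C=C/c2nnc(NC(=O)c3ccc(Cl)cc3)s2)c(Br)c(OC)c1OC`) follows from 4-chlorophenyl in place of 3-chlorophenyl on a carbonyl carbon. Among the compounds with values here, no measured pair moves one halogen in this way. The closest evidence is compound 2, the 4-bromophenyl case, at 160 nM, so a modest rise in the number is expected in this assay. The estimated change is a 1.7-fold higher number from compound 3 to compound 4 (0.23 log units; within the scatter). Compound 4 is expected at 120 nM, with an estimated range of 50 nM to 280 nM.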

Compound 4, half-maximal inhibitory concentration: 140 nM
Beside the measured number, compound 4's estimate is 1.2-fold (0.07 log units) below it; the range from low to high includes it.
By their numbers in this assay, from the lowest: compounds 1, 3, 4 and 2 (each within the scatter of the next, the first and the last beyond it).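

In this assay the swap of 3-chlorophenyl for 4-chlorophenyl on the carbonyl carbon gives a 2.0-fold higher number from compound 3 to compound 4 (0.30 log units; within the scatter) and so stays within the scatter, leaving no firm effect of the chlorine's placement. Chloro in place of bromo on the 4-substituted ring gives a 1.1-fold lower number from compound 2 to compound 4 (0.06 log units; within the scatter) and also stays within the scatter, so these two halogens cannot be told apart here. Only the comparison with 3-methoxyphenyl is beyond the scatter, with a 2.3-fold higher number from compound 1 to compound 4 (0.37 log units; beyond the scatter) as a modest step.

Nothing shown gives a reason for these steps. Open, as far as these compounds go, is how 3-bromophenyl, or a phenyl ring carrying an amine or a carboxylic acid, would read on this carbonyl carbon.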